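Swapping a fluorophenyl for a furan on the amine-linked carbon

The compounds below may be only part of what the source reports. "The series", "measured", "known", "first", "only" and "open" are said of these compounds alone.

Compound 1 `Cc1ccc2c(NCc3ccc(NC(=O)C4CCN(Cc5cccc(F)c5)CC4)cc3)nc(N(C)C)nc2c1`: in a functional assay on SV5A8 cells (Homo sapiens) for cytotoxicity (on this read-out lower numbers stand for stronger inhibition and higher numbers for weaker inhibition), compound 1 gives > 4170 nM, a limit of the assay rather than a number.
Compound 2 `Cc1ccc2c(NCc3ccc(NC(=O)C4CCN(Cc5ccccc5)CC4)cc3)nc(N3CCCC3)nc2c1`: in this assay compound 2 gives > 7790 nM, also a limit.
Compound 3 `CCN1CCN(c2nc(NCc3ccc(NC(=O)C4CCN(Cc5ccccc5)CC4)cc3)c3ccc(C)cc3n2)CC1`: in this assay compound 3 gives > 13000 nM, again a limit.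

Compound 1 therefore has no fixed place among the numbers shown: its own value is a limit, and the two other values are limits as well, so none of the three compounds can be ranked against another. Going by the values given here, the one step between measured compounds that differ in a single place, a step that the two limits leave unreadable from compound 2 to compound 3, cannot be sized, since the limits the limit of > 7790 nM in this assay, at which 1 of the 3 values shown sits, and the limit of > 13000 nM in this assay, at which 1 of the 3 values shown sits, both sit where the assay stops reading.

Compound 4 `Cc1ccc2c(NCc3ccc(NC(=O)C4CCN(Cc5ccco5)CC4)cc3)nc(N(C)C)nc2c1` differs from compound 1 in one place: furan-2-yl in place of 3-fluorophenyl on a saturated chain carbon bound to an amine nitrogen in a ring. Among the compounds with values here, no measured step touches this group, so nothing among the three compounds tells how large a change to expect in this assay, in either direction. The expectation is therefore that compound 4 stays in the same region, with the step that the limit leaves unreadable from compound 1 to compound 4 expected to be small and most likely again ending at a limit rather than a number. Compound 4 is estimated at 9000 nM, with a range from 3000 nM to 30000 nM.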

Compound 4, half-maximal inhibitory concentration: > 20000 nM
Compound 4: only a limit was reported; the forecaster's own chance of this, stated with the estimate: 80%; middle value at least 2.2-fold (0.34 log units) from the limit.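

Compound 1 and compound 4 both end at limits of this assay rather than at numbers, so the step from 3-fluorophenyl to furan-2-yl between them cannot be sized. The compounds shown leave open how strongly any of them inhibits in these cells, and whether this swap changes that at all.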